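Dropping the propoxy linker from a pyridinyl pyrimidine aniline

The source may hold more compounds than are shown below. What is called first, only, known or untested is meant among the compounds shown, and "the series" means these compounds.

Compound 1 `CN(C)CCCOc1ccc(Nc2nccc(-c3cccnc3)n2)cc1` has the lowest number of the two compounds measured in a functional assay for inhibition, with Homo sapiens as the target; on this read-out higher numbers stand for weaker inhibition and lower numbers for stronger inhibition: in this assay compound 1 gives 600 nM. Among the measured compounds shown here, the only other compound measured, compound 2 `CCN(CC)c1ccc(Nc2nccc(-c3ccc(C)o3)n2)cc1`, gives 28000 nM in this assay, a far higher number, and the two differ in more than one place, so no single change can be read from that pair. Compound 3 `CN(C)c1ccc(Nc2nccc(-c3cccnc3)n2)cc1` has not yet been measured. It differs from compound 1 in one place: dimethylamino in place of 3-(dimethylamino)propoxy on an aromatic carbon. For the measured compounds named here, no measured pair shows this change on its own. Compound 2 carries a dialkylamino group directly on the ring and gives 28000 nM, which points toward weaker inhibition, but its other difference clouds the reading. For compound 3 the expected step of a 5.0-fold higher number from compound 1 to compound 3 (0.70 log units; beyond the scatter) is a moderate rise beyond the scatter, and the estimated value for compound 3 is 3000 nM, with a range from 800 nM to 12000 nM.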

Compound 3, half-maximal inhibitory concentration: 2800 nM
Compound 3: the middle estimate sits 1.1-fold (0.03 log units) above what was measured; the range from low to high includes it.
By their numbers in this assay, from the lowest: compound 1; then compound 3; then compound 2.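

Among the compounds shown here, compound 3 gives the first reading of a single change at this place, on an aromatic carbon para to a large group. In this assay, putting dimethylamino in place of 3-(dimethylamino)propoxy brings a 4.7-fold higher number from compound 1 to compound 3 (0.67 log units; beyond the scatter) and so weakens inhibition, yet the step is modest and compound 3 still has a measurable number with the shorter group. Nothing shown here explains the rise.

The compounds shown leave open which part of the departing group carries the difference, the ether oxygen, the propyl chain or the terminal amine. Going by these compounds, a plain methoxy, a shorter 2-(dimethylamino)ethoxy chain, or a morpholine at the end of the propoxy chain would help separate these parts, and the effect of each remains unknown.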